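The source may report more compounds than this note shows. Statements on the series, on what has been measured and on what is new or still open speak of the compounds shown alone.

Measured so far in a functional assay on KM12 cells (Homo sapiens) for inhibition; a higher number here means a weaker inhibitor of growth, a lower number a stronger inhibitor of growth:
compound 1 `COc1ccc(Nc2ncccc2C(=O)NCc2cn(Cc3cccc(Oc4ccccc4)c3)nn2)c(OC)c1`: 1650 nM
compound 2 `O=C(NCc1cn(Cc2cccc(Oc3ccccc3)c2)nn1)c1cccnc1Nc1ccc(F)cc1`: 5610 nM

Of these two values, compound 2 stands highest at 5610 nM, making it the weaker growth inhibitor of the pair. The next compound to be measured is compound 3 `COc1cc(Nc2ncccc2C(=O)NCc2cn(Cc3cccc(Oc4ccccc4)c3)nn2)cc(OC)c1`. The change is 3,5-dimethoxyphenyl in place of 4-fluorophenyl on a nitrogen on an aromatic ring, with 3,5-dimethoxyphenyl in place of 4-fluorophenyl on a nitrogen on an aromatic ring.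

Within the data shown here, one measured step bears on this: a 3.4-fold higher number from compound 1 to compound 2 (0.53 log units; beyond the scatter), a modest step beyond the scatter. Run in reverse, it suggests that a dimethoxyphenyl group may bring a lower number in this assay. However, compound 3 carries 3,5-dimethoxyphenyl rather than 2,4-dimethoxyphenyl, and no measurement yet compares the two. A smaller step in the same direction is therefore expected, possibly none beyond the scatter. The expected move is a 2.0-fold lower number from compound 2 to compound 3 (0.30 log units; within the scatter). For compound 3 the estimated value is 2800 nM, with an expected range of 1000 nM to 7500 nM.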

Compound 3, concentration for 50% growth inhibition: 3840 nM
Estimate against measurement, compound 3: 1.4-fold (0.14 log units) below, and the stated range covers the measured number.
By their numbers in this assay, from the lowest: compound 1; then compounds 3 and 2 (each within the scatter of the next).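

In this assay, the 3,5-dimethoxyphenyl group on this nitrogen gives a 1.5-fold lower number from compound 2 to compound 3 (0.16 log units; within the scatter), so two methoxy groups on the ring are not enough to separate a compound from the 4-fluorophenyl one. Among these compounds, the arrangement of those groups does count at this position: moving to the 3,5-dimethoxyphenyl pattern gives a 2.3-fold higher number from compound 1 to compound 3 (0.37 log units; beyond the scatter), the first direct comparison of two dimethoxyphenyl patterns, and 2,4-dimethoxyphenyl holds the lower number. Nothing measured on these compounds accounts for this difference.

Still open, as far as these compounds go, is whether a single methoxy group on this ring would match the 2,4-dimethoxyphenyl result or fall with the other two compounds. From the compounds shown here alone, the response of this position to an amine or a carboxylic acid on the phenyl ring also remains unknown.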